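A few compounds are considered here, and "the series" means these few. Any claim that something is new, unique, unknown or untested is made for them only; others in the source may bear on it.

Among the compounds with values here, compound 1 `CC(C)N(C(=O)CN1C=CN(c2ccccc2)C(=O)C(Cc2n[nH]c3ccccc23)C1=O)c1ccc(F)cc1` is one of two compounds so far tested in a functional assay on CHO cells for agonist activity at Melanocortin receptor 4 (Homo sapiens), read by a luciferase reporter, with a stated time of 4 h; on this read-out lower numbers stand for an effect already at smaller amounts and higher numbers for an effect only at larger amounts of compound. In this assay compound 1 gives 282 nM, the lowest of the two numbers. Compound 2 `O=C1[C@H](Cc2n[nH]c3ccccc23)C(=O)N(c2ccccc2)C=CN1CC(=O)N1CCCCc2ccccc21` gives 794 nM, and the gap between these two lies beyond the usual scatter. Compound 3 `CC(C)N(C(=O)CN1C=CN(c2ccccc2)C(=O)C(Cc2n[nH]c3ccccc23)C1=O)c1ccccc1` has not yet been measured; it differs from compound 1 in one place: hydrogen in place of fluoro on an aromatic carbon. Within the data shown here, no measured pair shows this change, so no step can be read from the numbers. The expected step is small and, if anything, toward a higher number, about a 1.2-fold higher number from compound 1 to compound 3 (0.09 log units; within the scatter). For compound 3 the estimate is 350 nM, between 120 nM and 1000 nM.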

Compound 3, half-maximal effective concentration: 3240 nM
Compound 3: middle estimate off by 9.3-fold (0.97 log units), on the low side; measured number above the stated range.
By their numbers in this assay, from the lowest: compound 1; then compound 2; then compound 3.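

Swapping a single fluoro for hydrogen, 4-fluorophenyl to phenyl, with the rest of the molecule unchanged, gives an 11-fold higher number from compound 1 to compound 3 (1.06 log units; beyond the scatter) in this assay and is well beyond the usual scatter. This position, para to a large group, is therefore sensitive to even a one-atom change, which compounds 1 and 2 alone could not reveal. Nothing available explains the size of this step.

The compounds shown leave open whether chlorine, a methoxy group or an amine at this position would match fluoro. They also leave open whether fluoro elsewhere on this ring would do the same.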